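A few compounds are considered here, and "the series" means these few. Any claim that something is new, unique, unknown or untested is made for them only; others in the source may bear on it.

Measured compounds in the series:

compound 1, `CSc1nc(NCCCNc2ccnc3cc(Cl)ccc23)c(C#N)c(-c2ccccc2)n1`, 4700 nM
compound 2, `CSc1nc(NCCCCNc2ccnc3cc(Cl)ccc23)c(C#N)c(-c2ccccc2)n1`, 4400 nM

Both were run in an ADME assay on L1210 cells (Mus musculus) for inhibition, read by cell counting; on this read-out higher numbers stand for weaker inhibition and lower numbers for stronger inhibition. Compound 2 gives the lowest of the two numbers; compound 1 sits within the scatter of it, so the two show no difference that can be read as real.

The next compound, compound 3, `CSc1nc(NCCCCNc2ccnc3cc(Cl)ccc23)c(C#N)c(-c2cccc([N+](=O)[O-])c2)n1`, is still to be measured in this assay. It differs from compound 2 by nitro in place of hydrogen on an aromatic carbon.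

Going by the values given here, no step between two measured compounds covers such a change, so there is nothing in the numbers from which to read its size or direction. With only that to go on, the expectation for compound 3 is a value close to that of compound 2, with any shift likely to stay inside the scatter. Compound 3 is therefore estimated at 3800 nM, in a range from 1300 nM to 11000 nM, which corresponds to an expected step of a 1.2-fold lower number from compound 2 to compound 3 (0.06 log units; within the scatter).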

Compound 3, half-maximal inhibitory concentration: 2100 nM
Compound 3: the middle estimate sits 1.8-fold (0.26 log units) above what was measured; the range from low to high includes it.
By their numbers in this assay, from the lowest: compound 3; then compounds 2 and 1 (each within the scatter of the next).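

In this assay, going by these compounds alone, the change from phenyl to 3-nitrophenyl gives a 2.1-fold lower number from compound 2 to compound 3 (0.32 log units; beyond the scatter) and is the first difference that lies beyond the scatter, though only a modest one. Compound 1 and compound 2, which differ only in the chain, showed no readable difference, so the series had offered no measurable change until now. This aromatic carbon, meta to a large group, accepts nitro with a lower number rather than a higher one, and nothing available accounts for the step.

A single step cannot show whether the shift belongs to nitro itself or would also appear with an amine, a carboxylic acid or a methoxy group on the same carbon. Also open, on these data alone, is whether 3-nitrophenyl gives a similar step on the chain of compound 1.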